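The source may report more compounds than this note shows. Statements on the series, on what has been measured and on what is new or still open speak of the compounds shown alone.

Measured so far in an ADME assay on RAW264.7 cells (Mus musculus) for cytotoxicity, read by MTT assay, with a stated time of 24 h, in the absence of a further agent; on this read-out higher numbers stand for weaker inhibition and lower numbers for stronger inhibition:

- Compound 1 `COc1cc(OC)c2c(c1)C(C(O)c1ccc(O)cc1)OC2=O`: > 40000 nM
- Compound 2 `COc1ccc(C(O)C2OC(=O)c3c(OC)cc(OC)cc32)cc1`: > 40000 nM
- Compound 3 `CCCOc1ccc(C(O)C2OC(=O)c3c(OC)cc(OC)cc32)cc1`: > 40000 nM

Each of these entries is a limit of the assay and not a number. Compound 3 therefore has no exact value and shares its position with the other two: the limit of > 40000 nM in this assay, at which 3 of the 3 values shown sit.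

The next compound, compound 4 `CCCCOc1ccc(C(O)C2OC(=O)c3c(OC)cc(OC)cc32)cc1`, extends the propyl chain of compound 3 to butyl: methyl in place of hydrogen on a saturated chain carbon, three bonds along the chain from an oxygen on an aromatic ring.

For the measured compounds named here, the closest precedent is a step that the two limits leave unreadable from compound 2 to compound 3, which also lengthens the chain on that oxygen. The other two measured steps, a step that the two limits leave unreadable from compound 1 to compound 2 and a step that the two limits leave unreadable from compound 1 to compound 3, add a group to the same oxygen. None of the three has a readable size, so they offer no measured trend to extend. No step beyond the usual scatter is expected in this assay, and no direction can be favoured, so another limit is the likeliest report. The expected change is a step that the limit leaves unreadable from compound 3 to compound 4. Compound 4 is estimated at 55000 nM, with an expected range of 25000 nM to 120000 nM.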

Compound 4, half-maximal inhibitory concentration: > 40000 nM
Compound 4: a limit, no number; the forecaster's own chance of this, stated with the estimate: 85%; the middle value is on the limit's open side.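

Compound 4 is again a limit of the assay and not a number, so its steps from compound 1, compound 2 and compound 3 cannot be read: the limit of > 40000 nM in this assay, at which 4 of the 4 values shown sit. The compounds shown leave open what exact value any of these four compounds has in this assay, and whether chain length matters there.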